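Chloro to ethoxycarbonyl in the ethyl ester series

The source may hold more compounds than are shown below. What is called first, only, known or untested is meant among the compounds shown, and "the series" means these compounds.

Measured in a functional assay on the whole organism (strain Sprague-Dawley) for inhibition, with Rattus norvegicus as the target, with a stated time of 10 min; on this read-out lower numbers stand for an effect already at smaller amounts and higher numbers for an effect only at larger amounts of compound:
- compound 1 `CCOc1ccc(Cl)cc1-c1ncc(C(=O)O)c(=O)[nH]1`: 0.5 mg/kg
- compound 2 `CCOC(=O)c1cnc(-c2cccc3c2OC(C)C3)[nH]c1=O`: 5 mg/kg
- compound 3 `CCOC(=O)c1cnc(-c2cc(Cl)ccc2OCC)[nH]c1=O`: 0.5 mg/kg

Compound 3 stands level with compound 1 at the digits shown, and the two together hold the lowest number of the three. Compound 2 lies furthest from them at 5 mg/kg.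

Compound 4 `CCOC(=O)c1ccc(OCC)c(-c2ncc(C(=O)OCC)c(=O)[nH]2)c1` carries ethoxycarbonyl in place of chloro on an aromatic carbon, para to an ethoxy group: ethoxycarbonyl in place of chloro on an aromatic carbon.

For the measured compounds named here, the only measured step, no change at the digits printed from compound 1 to compound 3 (within the scatter), stayed within the scatter, but it concerns a different site and gives no direct guide to the loss of chloro. Going by the values given here, no measured pair isolates this replacement. Compound 2 also lacks chloro and gives 5 mg/kg, but it differs from compound 3 in more than that one place, so it is only a loose hint. A modest move towards a higher number in this assay is therefore expected, with wide uncertainty, and a result within the scatter is not excluded.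

The expected change is a 4.0-fold higher number from compound 3 to compound 4 (0.60 log units; beyond the scatter). In this assay compound 4 is estimated at 2 mg/kg, with an expected range of 0.5 mg/kg to 8 mg/kg.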

Compound 4, dose for 50% inhibition: 1 mg/kg
Compound 4: middle estimate off by 2.0-fold (0.30 log units), on the high side; the range from low to high includes it.
By their numbers in this assay, from the lowest: compounds 1, 3 and 4 (each within the scatter of the next); then compound 2.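

In this assay, for the compounds shown here, the exchange of chloro for ethoxycarbonyl on the aromatic carbon para to an ethoxy group gives a 2.0-fold higher number from compound 3 to compound 4 (0.30 log units; within the scatter), the first direct reading at this position, as the only earlier step concerned a different site. Within this one pair, chloro is not needed for the read-out to stay within the scatter, even though the entering group has 5 heavy atoms against 1 for chloro and brings 2 hydrogen-bond acceptors and a double bond outside aromatic rings. What lies behind this tolerance cannot be told from the material at hand, which contains no measurement that bears on it.

A single pair cannot show whether the same holds for other groups at this position, such as an amine, a carboxylic acid, a longer chain or plain hydrogen. Also open is whether no change at the digits printed from compound 1 to compound 3 (within the scatter), read with chloro at this position, would come out the same with ethoxycarbonyl there, since the acid counterpart of compound 4 is not among the compounds shown.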